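Furan-2-yl in place of thiophen-2-yl: an expected small step

This account rests on a few compounds, and the source may have more. Where it says the series, first, only, none or still open, it means among the compounds named here.

Compound 1, `COc1cc(-c2nnc3n2NC(c2ccco2)C(C(=O)c2ccccc2C)S3)cc(OC)c1OC`, gives 80000 nM in a functional assay on A549 cells (Homo sapiens) for cytotoxicity, read by MTT assay, with a stated time of 48 h; on this read-out higher numbers stand for weaker inhibition and lower numbers for stronger inhibition.
Compound 2, `COc1cc(-c2nnc3n2NC(c2ccco2)C(C(=O)c2ccc(F)cc2)S3)cc(OC)c1OC`, gives 53700 nM in this assay.
Compound 3, `COc1cc(-c2nnc3n2NC(c2cccs2)C(C(=O)c2ccccc2)S3)cc(OC)c1OC`, gives 69400 nM in this assay.

All three compounds share one core and differ only in the groups attached to it. Compound 3 stands second highest of the three numbers, yet its value lies within the usual scatter of both compound 1 and compound 2, so the three cannot be ranked against each other. Going by the values given here, the one step recorded between measured compounds is a 1.5-fold lower number from compound 1 to compound 2 (0.17 log units; within the scatter), and it concerns the group on the carbonyl carbon, not the group on the saturated ring carbon.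

Compound 4, `COc1cc(-c2nnc3n2NC(c2ccco2)C(C(=O)c2ccccc2)S3)cc(OC)c1OC`, is not yet measured. It differs from compound 3 in one place: furan-2-yl in place of thiophen-2-yl on a saturated ring carbon. Among the compounds with values here, no measured step touches this position, so there is nothing to point toward a change in either direction. Within the data shown here, the only guidance is that the three measured values sit close together, whatever the group exchanged.

For that reason compound 4 is expected to give about 69400 nM in this assay, somewhere between 33000 nM and 145000 nM, which would mean an expected step of no change at the digits printed from compound 3 to compound 4 (within the scatter), not beyond the scatter.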

Compound 4, half-maximal inhibitory concentration: 33400 nM
Compound 4: middle estimate off by 2.1-fold (0.32 log units), on the high side; low and high end bracket the measured number.
By their numbers in this assay, from the lowest: compounds 4, 2, 3 and 1 (each within the scatter of the next, the first and the last beyond it).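

In this assay, going by these compounds alone, the saturated ring carbon proves sensitive to an exchange of one five-membered aromatic ring for another: furan-2-yl in place of thiophen-2-yl gives a 2.1-fold lower number from compound 3 to compound 4 (0.32 log units; beyond the scatter) and is the first measured step at this position. With furan-2-yl held in place, hydrogen in place of methyl on an aromatic carbon gives a 2.4-fold lower number from compound 1 to compound 4 (0.38 log units; beyond the scatter) and so also counts as a modest change, whereas hydrogen in place of fluoro gives a 1.6-fold lower number from compound 2 to compound 4 (0.21 log units; within the scatter) and cannot be read as a real difference. Nothing available explains why replacing the sulfur of this ring with oxygen, with the heavy-atom count unchanged, shifts the number.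

On these data alone, only these two rings appear on the saturated ring carbon, so it remains open whether a phenyl ring, a pyridin-3-yl ring or an open chain such as propyl would shift the number further or reverse the step. As far as these compounds go, it also remains open whether the exchange of thiophen-2-yl for furan-2-yl would give a similar step in compounds carrying the fluoro or methyl group on the benzoyl ring.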